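The compounds below may be only part of what the source reports. "The series", "measured", "known", "first", "only" and "open" are said of these compounds alone.

Working notes on the series. Compound 2 `COc1cc(-c2nn(-c3cccc(NC(=O)c4cccc(C(F)(F)F)c4)c3)cc2-c2ccncc2)ccc1Cl` and compound 1 `COc1cc(-c2nn(-c3cccc(NC(=O)Nc4cc(C(F)(F)F)cc(C(F)(F)F)c4)c3)cc2-c2ccncc2)ccc1Cl` share a core and differ at the group carried by the carbonyl attached to the aniline nitrogen. In a functional assay on SF-295 cells (Homo sapiens) for inhibition, read by sulforhodamine B assay, with a stated time of 48 h (on this read-out higher numbers stand for weaker inhibition of growth and lower numbers for stronger inhibition of growth), compound 1 gives 1230 nM. In this assay compound 2 gives 3000 nM, the highest of the two numbers at hand, and its gap to compound 1 lies beyond the usual scatter of repeated measurements.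

Compound 3 `COc1cc(-c2nn(-c3cccc(NC(=O)Nc4ccc(Cl)c(Cl)c4)c3)cc2-c2ccncc2)ccc1Cl` is the next compound to be measured in this assay. The change from compound 2 is (3,4-dichlorophenyl)amino in place of 3-(trifluoromethyl)phenyl on a carbonyl carbon. With it, compound 3 carries the same carbamoyl link as compound 1, while the aromatic ring on the far side carries two chlorines in place of the trifluoromethyl groups.

Only one point of reference exists: the carbamoyl link of compound 1 reads lower in this assay than the carbonyl link of compound 2. The step from compound 2 to compound 3 is therefore expected to run downward, about a 2.0-fold lower number from compound 2 to compound 3 (0.30 log units; within the scatter), because compound 1 gives 1230 nM in this assay. For compound 3 the estimate in this assay is 1500 nM, with the likely range set from 600 nM to 4000 nM.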

Compound 3, concentration for total growth inhibition: 2530 nM
Compound 3: the middle estimate sits 1.7-fold (0.23 log units) below what was measured; low and high end bracket the measured number.
By their numbers in this assay, from the lowest: compound 1; then compounds 3 and 2 (each within the scatter of the next).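

In this assay the exchange of 3-(trifluoromethyl)phenyl for (3,4-dichlorophenyl)amino on a carbonyl carbon gives a 1.2-fold lower number from compound 2 to compound 3 (0.07 log units; within the scatter), so replacing the link and the ring substituents together leaves no readable change at this position. The carbamoyl link therefore does not by itself go with the lowest number in the series: compound 3 carries that link yet stands with compound 2, whereas compound 1, which has the same link with trifluoromethyl groups on its far ring, gives 1230 nM as the lowest of the three numbers. Nothing at hand offers an explanation for how these compounds read.

This single step changes the link and the ring substituents at once, and the compounds shown do not separate the contribution of each, which would need the 3-(trifluoromethyl)phenyl ring on the carbamoyl link. Also open, on these data alone, is how the carbamoyl link would read in this assay with a far ring bearing a nitrile or a morpholine, or with a plain phenyl ring.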